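Chloro to Trifluoromethyl: Expected Aortic Maximal Response

This account rests on a few compounds, and the source may have more. Where it says the series, first, only, none or still open, it means among the compounds named here.

Compound 1, `O=C1C=CC(=O)c2cnccc21`: 92%
Compound 2, `O=C1C(Nc2cccc(F)c2)=CC(=O)c2ncccc21`: 85%
Compound 3, `O=C1C(Nc2ccc(Cl)cc2)=CC(=O)c2ncccc21`: 86%

In a functional assay on the whole organism (aorta) with Rattus norvegicus as the target (on this read-out lower numbers stand for smaller maximal responses and higher numbers for larger maximal responses), compound 3 gives 86%, the second highest of the three numbers. Compound 2 sits nearest to it and compound 1 furthest, yet both gaps fall within the usual scatter, so none of the three can be ranked against another. Compound 4, `O=C1C(Nc2ccc(C(F)(F)F)cc2)=CC(=O)c2ncccc21`, has not yet been measured. Its difference from compound 3 is trifluoromethyl in place of chloro on an aromatic carbon. Within the data shown here, no measured pair shows a comparable change, so no measured step can guide the expectation. Because compound 3 gives 86% and the other two known values lie within the scatter of it, a step of no more than the scatter, with no clear direction, is expected: no change at the digits printed from compound 3 to compound 4 (within the scatter). Compound 4 is accordingly estimated at 86%, with a range from 74% to 97%.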

Compound 4, largest response reached (Emax), in percent of the reference or control that the assay uses: 91%
The estimate for compound 4 lay 5 percentage points below the measured number, and the stated range covers the measured number.
By their numbers in this assay, from the lowest: compounds 2, 3, 4 and 1 (each within the scatter of the next).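

The step shows that in this assay trifluoromethyl in place of chloro on an aromatic carbon, para to a large group, gives a number 5 percentage points higher from compound 3 to compound 4 (within the scatter) and so this position accepts the larger group without a change beyond the scatter. Nothing at hand accounts for the size of this step. Going by these compounds, whether an amine, a carboxylic acid or a longer chain at this position would also stay within the scatter remains open. So does whether the same exchange would behave alike elsewhere on that ring.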